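The compounds below may be only part of what the source reports. "The series", "measured", "known", "first", "only" and "open" are said of these compounds alone.

Working notes on the series.

Three compounds are measured in a functional assay on SK-OV-3 cells (Homo sapiens) for antiproliferative activity, read by MTT assay, with a stated time of 72 h; on this read-out lower numbers stand for stronger inhibition and higher numbers for weaker inhibition. Compound 2 `COc1ccc(NC(=O)CCc2cccc3c2B(O)OC3)cc1` gives 900 nM in this assay. Compound 1 `C#Cc1ccc(NC(=O)CCc2cccc3c2B(O)OC3)cc1` gives 6300 nM. Compound 3 `COc1ccccc1NC(=O)CCc1cccc2c1B(O)OC2` gives 200 nM, the lowest of the three numbers. Compound 2 and compound 3 have the same atoms joined differently; the difference between the two cores is not broken down here, and the two values alone show that compound 3 stands lower in this assay than compound 2.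

One change is seen twice in the set. From compound 2 to compound 1 it is ethynyl in place of methoxy on an aromatic carbon, and it produced a 7.0-fold higher number from compound 2 to compound 1 (0.85 log units; beyond the scatter). Compound 4 `C#Cc1ccccc1NC(=O)CCc1cccc2c1B(O)OC2` has not yet been measured; it arises from compound 3 by ethynyl in place of methoxy on an aromatic carbon. The two changes are of the same kind, not the same: in the first the group sits para to a large group, in the second ortho to a large group.

Among the compounds with values here, the expectation for compound 4 in this assay rests on the single measured instance of the change. Because the step of a 7.0-fold higher number from compound 2 to compound 1 (0.85 log units; beyond the scatter) was modest but beyond the scatter, a step of similar direction is expected from compound 3 to compound 4, estimated as a 6.0-fold higher number from compound 3 to compound 4 (0.78 log units; beyond the scatter). The different surroundings of the place mean the size of the step carries real uncertainty, so the expected range is kept wide. Compound 4 is estimated at 1200 nM in this assay, with an expected range from 400 nM to 4000 nM.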

Compound 4, half-maximal inhibitory concentration: 820 nM
Estimate against measurement, compound 4: 1.5-fold (0.17 log units) above; the range from low to high includes it.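

Replacing methoxy with ethynyl on the second core again moves the number upward in this assay, with a 4.1-fold higher number from compound 3 to compound 4 (0.61 log units; beyond the scatter), so the direction seen on the first core recurs. Across the cores of compound 2 and compound 3, the step carries over in direction and its size does not separate from the earlier one: the same change on two cores in this assay, a 7.0-fold higher number (0.85 log units; beyond the scatter) from compound 2 to compound 1 and a 4.1-fold higher number (0.61 log units; beyond the scatter) from compound 3 to compound 4, 1.7-fold (0.23 log units) apart, within the scatter of two such steps. Within the data shown here, this shows only that the change transferred between these two closely related cores in this one assay, with the ethynyl group placed differently on the aromatic ring in each pair; two pairs do not establish a rule for other cores, and they give no explanation for the loss of antiproliferative activity.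

The compounds shown leave open whether an amine, a carboxylic acid, a nitrile or a longer chain at the same aromatic carbon would give a step in the same direction as ethynyl, or whether any such group would match or improve on methoxy. They also leave open whether the same replacement would keep its direction on a core with a longer chain in place of the one that carries the amide, and whether it would do so on other cell lines.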